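Swapping the chain on the ring nitrogen of compound 2

This account rests on a few compounds, and the source may have more. Where it says the series, first, only, none or still open, it means among the compounds named here.

The series shares one core, shown in compound 1 `NNc1nonc1/C(=N/O)Nc1ccc(F)c(Br)c1`, whose nitrogen on the aromatic ring carries a free amino group. In an assay on isolated protein for inhibition of Indoleamine 2,3-dioxygenase 1 (Homo sapiens), read by fluorescence, with a stated time of 60 min (a higher number here means a weaker inhibitor, a lower number a stronger inhibitor), compound 1 gives 108 nM. Compound 2 `NNS(=O)(=O)CCNc1nonc1/C(=N/O)Nc1ccc(F)c(Br)c1` extends that nitrogen by a 2-(aminosulfamoyl)ethyl chain, and in this assay compound 2 gives 135 nM. Among the two numbers in hand, compound 2 has the higher one, yet the step of a 1.3-fold higher number from compound 1 to compound 2 (0.10 log units; within the scatter) shows that substitution on this nitrogen left the read-out essentially where it was.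

Compound 3 `NS(=O)(=O)CCONc1nonc1/C(=N/O)Nc1ccc(F)c(Br)c1` changes the same chain: 2-sulfamoylethoxy in place of 2-(aminosulfamoyl)ethyl on a nitrogen on an aromatic ring. Among the compounds with values here, the one measured step that bears on this position, from compound 1 to compound 2, is within the scatter, so the ring nitrogen appears to tolerate a chain of this size without a clear shift. On that basis the step is expected to be small, no change at the digits printed from compound 2 to compound 3 (within the scatter), with no direction claimed beyond the scatter. Compound 3 is therefore estimated at 135 nM, with a plausible range from 60 nM to 320 nM.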

Compound 3, half-maximal inhibitory concentration: 87 nM
For compound 3 the middle estimate is 1.6-fold (0.19 log units) above the measured one; the measured number falls inside the stated range.
By their numbers in this assay, from the lowest: compounds 3, 1 and 2 (each within the scatter of the next).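

In this assay, 2-sulfamoylethoxy in place of 2-(aminosulfamoyl)ethyl gives a 1.6-fold lower number from compound 2 to compound 3 (0.19 log units; within the scatter) and, set against the free amino group, the same chain gives a 1.2-fold lower number from compound 1 to compound 3 (0.09 log units; within the scatter). The earlier pair showed only that one chain on this nitrogen on an aromatic ring left the number within the scatter of the amino compound; now a second chain of 7 heavy atoms, with an oxygen attached to that nitrogen and a different count of hydrogen-bond donors, does the same, so compounds 1, 2 and 3 cannot be told apart in this assay. No supporting measurement is available to explain why these three compounds read alike.

The chains shown are uncharged and open, so it remains open whether this nitrogen would accept a chain ending in a carboxylic acid or an amine, a longer chain, or a chain carrying a ring without leaving the scatter. Going by these compounds, it is also open whether compounds 1, 2 and 3 would still read alike in any setting other than this assay on isolated protein.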